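The source may hold more compounds than are shown below. What is called first, only, known or untested is meant among the compounds shown, and "the series" means these compounds.

Compound 2, `C=CC1=C(C(=O)NCCC)C(c2ccc(F)cc2)OC1`, is the starting point. In a functional assay on A549 cells (Homo sapiens) for cytotoxicity, read by MTT assay, with a stated time of 24 h (a higher number here means a weaker inhibitor, a lower number a stronger inhibitor), compound 2 gives > 100000 nM, which is a limit of the assay rather than a measured number. Compound 1, `C=CC1=C(C(=O)NCc2ccccc2F)C(c2ccc(F)cc2)OC1`, is related to compound 2 by ethyl in place of 2-fluorophenyl on a saturated chain carbon bound to an amide-type nitrogen. In this assay compound 1 gives > 100000 nM, again a limit. Compound 3, `C=CC1=C(C(=O)NCCC)C(c2ccc(OC)cc2)OC1`, carries methoxy in place of fluoro on an aromatic carbon. In this assay compound 3 gives > 100000 nM, also a limit. The step from compound 1 to compound 2 reads a step that the two limits leave unreadable from compound 1 to compound 2, and the step from compound 2 to compound 3 reads a step that the two limits leave unreadable from compound 2 to compound 3, because of the limit of > 100000 nM in this assay, at which 3 of the 3 values shown sit.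

Compound 4, `C=CC1=C(C(=O)NCc2ccccc2)C(c2ccc(F)cc2)OC1`, differs from compound 2 by phenyl in place of ethyl on a saturated chain carbon bound to an amide-type nitrogen. The two measured steps bear on this change only in that neither could be read, so no size and no direction can be drawn from them. The step from compound 2 to compound 4 is therefore expected to be a step that the limit leaves unreadable from compound 2 to compound 4, with a further limit the most likely outcome. Compound 4 is estimated at 150000 nM in this assay, within a range from 50000 nM to 500000 nM.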

Compound 4, half-maximal inhibitory concentration: > 100000 nM
Compound 4: a limit, no number (the forecaster's own chance of this, stated with the estimate: 80%); the middle value is on the limit's open side.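

In this assay compound 4 gives > 100000 nM, which is a limit, so the steps to it from compound 1 and from compound 2 cannot be read: the limit of > 100000 nM in this assay, at which 4 of the 4 values shown sit.

The compounds shown leave open whether any of these changes alters cytotoxicity at all, and in which direction.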